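The compounds below may be only part of what the source reports. "The series", "measured", "known", "first", "only" and "open" are said of these compounds alone.

Measured so far in a functional assay on HCT-15 cells (Homo sapiens) for antiproliferative activity, read by XTT assay; on this read-out higher numbers stand for weaker inhibition and lower numbers for stronger inhibition:
- compound 1, `O=c1c(Cc2coc3cccc(OCC4CCCCC4)c3c2=O)coc2ccccc12`: 4240 nM
- compound 2, `O=c1c(Cc2coc3ccccc3c2=O)coc2ccccc12`: > 10000 nM, which is a limit of the assay and not a number

Compound 2 therefore stands at the top of the measured range, (the limit of > 10000 nM in this assay, at which 1 of the 2 values shown sits). Compound 3, `O=c1c(Cc2coc3cccc(O)c3c2=O)coc2ccccc12`, differs from compound 2 by hydroxy in place of hydrogen on an aromatic carbon, the same carbon that carries cyclohexylmethoxy in compound 1. For the measured compounds named here, the only step that bears on this is an at least 2.3-fold higher number from compound 1 to compound 2 (0.37 log units; beyond the scatter), which removed a substituent at that carbon. Putting a much smaller group back is expected to recover some of that, estimated as an at least 1.4-fold lower number from compound 2 to compound 3 (0.15 log units; that floor lies within the scatter). Compound 3 is estimated at 7000 nM, within 2500 nM to 20000 nM.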

Compound 3, half-maximal inhibitory concentration: > 10000 nM
Compound 3: a limit, no number (the forecaster's own chance of this, stated with the estimate: 45%); at least 1.4-fold (0.15 log units) between middle value and limit.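

In this assay, taking cyclohexylmethyl off the oxygen gives an at least 2.3-fold higher number from compound 1 to compound 3 (0.37 log units; beyond the scatter), so at this aromatic carbon a free hydroxy does not keep what cyclohexylmethoxy gives. A hydroxy group alone therefore brings no readable gain in this series. Compound 2 and compound 3 sit at the same limit of the assay, and the step between them cannot be read: the limit of > 10000 nM in this assay, at which 2 of the 3 values shown sit.

Still open, on these data alone, is whether methoxy or an amine at this carbon would come off that limit. Also open, as far as these compounds go, is whether the cyclohexyl ring is needed, or whether an open butyl chain on the oxygen would serve as well.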